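The source may hold more compounds than are shown below. What is called first, only, known or untested is meant among the compounds shown, and "the series" means these compounds.

Within the data shown here, compound 1 `OCc1cn(Cc2ccccc2)c2ccccc12` is the only compound here with an actual number rather than a limit: in an ADME assay on T29 cells (Homo sapiens) for cytotoxicity, read by sulforhodamine B assay, with a stated time of 3 days (on this read-out lower numbers stand for stronger inhibition and higher numbers for weaker inhibition), compound 1 gives 14500 nM. Compound 2 `OCc1cn(Cc2cccc(F)c2)c2ccccc12` reaches only the limit of the test, giving > 31600 nM in this assay. Compound 3 `OCc1cn(Cc2cccc(I)c2)c2ccccc12` likewise gives only the limit > 31600 nM. Both an at least 2.1-fold higher number from compound 1 to compound 2 (0.33 log units; beyond the scatter) and an at least 2.1-fold higher number from compound 1 to compound 3 (0.33 log units; beyond the scatter); in each case the limit of > 31600 nM in this assay, at which 2 of the 3 values shown sit, is all that can be read. Compound 4 `Cc1ccc(Cn2cc(CO)c3ccccc32)cc1` has not been measured and differs from compound 1 by methyl in place of hydrogen on an aromatic carbon. Going by those two steps, a further group on an aromatic carbon is expected to raise the number, though the limit may hide how far. Compound 4 is therefore expected to give 25000 nM, between 10000 nM and 45000 nM, which would be a 1.7-fold higher number from compound 1 to compound 4 (0.24 log units; within the scatter).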

Compound 4, half-maximal inhibitory concentration: > 31600 nM
Compound 4: no number, only a limit (the forecaster's own chance of this, stated with the estimate: 45%); middle value at least 1.2-fold (0.10 log units) from the limit.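

Methyl, on an aromatic carbon para to a large group, gives an at least 2.1-fold higher number from compound 1 to compound 4 (0.33 log units; beyond the scatter). The rise in the number in this assay is therefore not confined to the halogens fluoro and iodo, as a small carbon group with no hydrogen-bond donors or acceptors does the same. Compound 2, compound 3 and compound 4 cannot be ranked against one another, because all stop at the same limit: the limit of > 31600 nM in this assay, at which 3 of the 4 values shown sit.

Still open, as far as these compounds go, is whether an amine or a carboxylic acid here would also raise the number. Also open, from the compounds shown here alone, is whether any group at this position could lower it below that of compound 1.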